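The source may hold more compounds than are shown below. What is called first, only, known or untested is meant among the compounds shown, and "the series" means these compounds.

Measured compounds:
- Compound 1 `COc1cc(/C=C/C(=O)c2cccc(-n3cc(-c4ccc(Cl)cc4)[nH]c3=O)c2)cc(OC)c1OC`: 16100 nM
- Compound 2 `O=C(/C=C/c1cccc(O)c1)c1cccc(-n2cc(-c3ccccc3)[nH]c2=O)c1`: 10900 nM
- Compound 3 `COc1ccc(-c2cn(-c3cccc(C(=O)/C=C/c4ccc(O)c(OC)c4)c3)c(=O)[nH]2)cc1`: 5840 nM

All three were tested in a functional assay on SNB-19 cells (Homo sapiens) for inhibition; on this read-out lower numbers stand for stronger inhibition of growth and higher numbers for weaker inhibition of growth. Compound 1 carries the highest of the three numbers in this assay. Compound 2 sits close to it, and the two values lie within the usual scatter of each other, so they cannot be told apart. Compound 3 gives a clearly lower number than compound 1, a gap that lies beyond the scatter, which marks compound 3 as the stronger growth inhibitor of that pair.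

The unmeasured compound 4 `COc1cc(/C=C/C(=O)c2cccc(-n3cc(-c4cc(OC)c(OC)c(OC)c4)[nH]c3=O)c2)cc(OC)c1OC` is built from compound 1 by one change: 3,4,5-trimethoxyphenyl in place of 4-chlorophenyl on an aromatic carbon. Within the data shown here, compound 2 and compound 3 share neither the trimethoxy side of compound 1 nor the new group, so there is no direct precedent for this exact swap. A step of modest size toward a lower number is expected from compound 1 to compound 4 a 2.0-fold lower number from compound 1 to compound 4 (0.30 log units; within the scatter), partly because compound 3, whose phenyl bears a methoxy, gives 5840 nM. For compound 4 the expected value in this assay is 8000 nM, with a likely range from 2500 nM to 25000 nM.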

Compound 4, concentration for 50% growth inhibition: 4070 nM
For compound 4 the middle estimate is 2.0-fold (0.29 log units) above the measured one; the range from low to high includes it.
By their numbers in this assay, from the lowest: compounds 4, 3, 2 and 1 (each within the scatter of the next, the first and the last beyond it).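

Placing 3,4,5-trimethoxyphenyl in place of 4-chlorophenyl on the aromatic carbon of the five-membered ring gives, in this assay, a 4.0-fold lower number from compound 1 to compound 4 (0.60 log units; beyond the scatter). This is the first change among these compounds that can be read in one place, and it shows that the aryl group at this position is not interchangeable: a larger group carrying hydrogen-bond acceptors, where the 4-chlorophenyl has none, is tolerated here and goes with stronger inhibition of growth in this single pair. Nothing available here says which feature of the swap accounts for the step, whether the loss of the chlorine, the added methoxy groups or the larger size of the group.

On these data alone, it remains open whether a single methoxy group on this phenyl ring, with the rest of compound 1 unchanged, would give a step of similar size or whether all three are needed. Also open, as far as these compounds go, is how a different kind of group on this ring, such as an amine or a carboxylic acid, would shift the number.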